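The compounds below may be only part of what the source reports. "The series", "measured", "known", "first", "only" and "open" are said of these compounds alone.

The measured compounds and their numbers:

compound 1 `COc1ccc(-c2cc(C(=O)/C=C/c3ccccc3)nc3cc(-c4ccccc4)nn23)cc1OC` — 23300 nM
compound 2 `COc1cc(-c2cc(C(=O)/C=C/c3ccccc3)nc3cc(-c4ccccc4)nn23)cc(OC)c1OC` — 19200 nM
compound 3 `COc1ccc(/C=C/C(=O)c2cc(-c3cc(OC)c(OC)c(OC)c3)n3nc(-c4ccccc4)cc3n2)cc1OC` — 14200 nM

In a functional assay on MDA-MB-231 cells (Homo sapiens) for antiproliferative activity, read by MTT assay, with a stated time of 24 h (a lower number here means a stronger inhibitor, a higher number a weaker inhibitor), compound 2 gives 19200 nM, the second highest of the three numbers. Its nearest neighbour is compound 1, with a 1.2-fold lower number from compound 1 to compound 2 (0.08 log units; within the scatter), and its furthest is compound 3, with a 1.4-fold lower number from compound 2 to compound 3 (0.13 log units; within the scatter); both steps stay within the scatter, so the three numbers cannot be told apart.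

Compound 4 `COc1cc(-c2cc(/C=C/C(=O)c3ccc(Cl)cc3)nc3cc(-c4ccccc4)nn23)cc(OC)c1OC` differs from compound 2 in one place: 2-((4-chlorophenyl)carbonyl)ethenyl in place of (2-phenylethenyl)carbonyl on an aromatic carbon. Among the compounds with values here, two measured steps bear on this change, though neither matches it. The step from compound 1 to compound 2 adds a methoxy on an aromatic carbon and is within the scatter. The step from compound 2 to compound 3 swaps the phenyl at the end of the chain for a 3,4-dimethoxyphenyl and is also within the scatter. Within the data shown here, no measured pair reverses the order of the carbonyl and the ethenyl unit, and no measured pair carries a chlorine, so the data give no direction for this change. Compound 4 is therefore expected to give a number close to compound 2, with a 1.1-fold lower number from compound 2 to compound 4 (0.05 log units; within the scatter) expected to be no larger than the scatter. The estimate for compound 4 in this assay is 17000 nM, with a range from 5000 nM to 55000 nM.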

Compound 4, half-maximal inhibitory concentration: 32500 nM
The estimate for compound 4 lay 1.9-fold (0.28 log units) below the measured number; the measured number falls inside the stated range.
By their numbers in this assay, from the lowest: compounds 3, 2, 1 and 4 (each within the scatter of the next, the first and the last beyond it).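

Within the data shown here, the first measured change at this position, on the aromatic carbon next to the ring nitrogen, swaps (2-phenylethenyl)carbonyl for 2-((4-chlorophenyl)carbonyl)ethenyl, which reverses the order of the carbonyl and the ethenyl unit and brings in a chlorine on the end phenyl ring. In this assay, this gives a 1.7-fold higher number from compound 2 to compound 4 (0.23 log units; within the scatter), so compound 2 and compound 4 cannot be told apart, and neither the reversed chain combined with the chlorine nor the extra heavy atom produces a step beyond the scatter at this position. No evidence is available that would explain this result.

The two alterations arrive together in compound 4, so the compounds shown leave open what the reversed chain does without the chlorine and what the chlorine does on the original (2-phenylethenyl)carbonyl chain. Also open, going by these compounds, is whether an amine or a carboxylic acid in place of the chlorine on the end phenyl ring, or a longer chain between that ring and the shared core, would give a step beyond the scatter.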